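Adding a Second Methoxy Group: Expected Cell Toxicity

The compounds below may be only part of what the source reports. "The series", "measured", "known", "first", "only" and "open" are said of these compounds alone.

Compound 1, `COc1cccc(NC(=O)COc2cc(C)nc3ccc(OC)cc23)c1`: in an ADME assay on HepG2 cells (Homo sapiens) for cytotoxicity, read by trypan blue exclusion, with a stated time of 48 h, in the presence of a further agent that is not named here (on this read-out lower numbers stand for higher toxicity in this test and higher numbers for lower toxicity in this test), compound 1 gives 43000 nM.
Compound 2, `COc1ccc(NC(=O)COc2cc(C)nc3ccc(OC)cc23)cc1`: in this assay compound 2 gives only a limit, > 142000 nM.

Compound 2 therefore stands at the assay limit rather than at a number (the limit of > 142000 nM in this assay, at which 1 of the 2 values shown sits). Compound 3, `COc1ccc2nc(C)cc(OCC(=O)Nc3ccc(OC)c(OC)c3)c2c1`, differs from compound 2 by methoxy in place of hydrogen on an aromatic carbon. Among the compounds with values here, the only measured step, an at least 3.3-fold higher number from compound 1 to compound 2 (0.51 log units; beyond the scatter), concerns a different change and bears on this one only loosely. With compound 2 already at the limit, no step beyond the scatter in this assay is expected. Compound 3 is expected to give 150000 nM, in the range 50000 nM to 450000 nM. The expected step is a step that the limit leaves unreadable from compound 2 to compound 3.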

Compound 3, half-maximal cytotoxic concentration: > 131000 nM
Compound 3 was reported as a limit (the forecaster's own chance of this, stated with the estimate: 60%); the middle value does not contradict the limit.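

In this assay, compound 3 also ends at a limit of the assay rather than at a number, and the step that adds the methoxy group to compound 2 cannot be read. Within the data shown here, the added methoxy group, ortho to a methoxy group, still does not return the read-out to the lower number seen with the single methoxy group on compound 1; the comparison gives an at least 3.0-fold higher number from compound 1 to compound 3 (0.48 log units; beyond the scatter).

From the compounds shown here alone, how far the true values of the two limited compounds lie beyond their limits remains open. So does whether an amine or a carboxylic acid at this position would give a number that can be read.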